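Bromo, chloro, then methoxy on the shared core

A few compounds are considered here, and "the series" means these few. Any claim that something is new, unique, unknown or untested is made for them only; others in the source may bear on it.

Measured compounds:
compound 1 `COC(=O)[C@@]1(C)CC[C@@H]2C3=C1CC[C@@H](C)[C@]3(C)C[C@@H]1c3cc(Br)ccc3N[C@H]21` — 31000 nM
compound 2 `COC(=O)[C@@]1(C)CC[C@@H]2C3=C1CC[C@@H](C)[C@]3(C)C[C@@H]1c3cc(Cl)ccc3N[C@H]21` — 28000 nM

In a functional assay on T47D cells (Homo sapiens) for inhibition, read by sulforhodamine B assay, with a stated time of 48 h (on this read-out higher numbers stand for weaker inhibition of growth and lower numbers for stronger inhibition of growth), compound 1 gives 31000 nM, and compound 2 gives 28000 nM. Within the data shown here, the only step between measured compounds, a 1.1-fold lower number from compound 1 to compound 2 (0.04 log units; within the scatter), is a swap of one halogen for another on the aromatic carbon, and it changes nothing beyond the scatter. Compound 2 therefore holds the lowest of the two numbers, but its separation from compound 1 is within the scatter, so the two compounds cannot be ordered against each other.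

Compound 3 `COC(=O)[C@@]1(C)CC[C@@H]2C3=C1CC[C@@H](C)[C@]3(C)C[C@@H]1c3cc(OC)ccc3N[C@H]21` continues from compound 2 with methoxy in place of chloro on an aromatic carbon. Among the measured compounds shown here, no measured step replaces a halogen with methoxy, so the bromo-to-chloro step is the only guide, and it was flat. With that single flat step as the sole reference, the expectation is that the number for compound 3 stays near that of compound 2, with the uncertainty widened because the entering group differs in kind from anything measured. Compound 3 is estimated at 30000 nM (range 12000 nM to 75000 nM), which is expected to correspond to a 1.1-fold higher number from compound 2 to compound 3 (0.03 log units; within the scatter).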

Compound 3, concentration for 50% growth inhibition: 19000 nM
Beside the measured number, compound 3's estimate is 1.6-fold (0.20 log units) above it, and the stated range covers the measured number.
By their numbers in this assay, from the lowest: compounds 3, 2 and 1 (each within the scatter of the next).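

Among these compounds, until now the only change at this aromatic carbon had been one halogen for another, so nothing showed how the position answers to a group of a different kind; methoxy, which brings carbon and oxygen where the halogen stood, supplies that test. In this assay the change gives a 1.5-fold lower number from compound 2 to compound 3 (0.17 log units; within the scatter) and a 1.6-fold lower number from compound 1 to compound 3 (0.21 log units; within the scatter) so that neither step separates methoxy from the halogen it replaces, and bromo, chloro and methoxy cannot be ordered against one another at this carbon. Nothing available bears on why the numbers fall as they do.

All three compounds therefore sit together in the same part of the scale, and the compounds shown do not tell whether any group at this carbon can move the number beyond the scatter, for instance an amine, a carboxylic acid or a longer chain such as butoxy. They also leave open what the bare aromatic carbon with only hydrogen would give, and whether the other aromatic carbons of this ring respond any differently from this one.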